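A Methyl for Methoxy at the Lower Number

The compounds below may be only part of what the source reports. "The series", "measured", "known", "first", "only" and "open" are said of these compounds alone.

In an ADME assay on the whole organism (Mus musculus, strain CD-1) for pharmacokinetics, at a dose of 10 mg/kg by the oral route (on this read-out lower numbers stand for lower oral bioavailability and higher numbers for higher oral bioavailability), compound 1 `COc1cc([C@](O)(CCN(C)C)[C@@H](c2cc3cc(C#N)ccc3nc2OC)c2cccc(C)c2F)cc(OC(F)F)n1` gives 66% and compound 2 `COc1cccc([C@H](c2cc3cc(C#N)ccc3nc2OC)[C@@](O)(CCN(C)C)c2cc(SC)nc(SC)c2)c1F` gives 28% as its reading. Compound 2 therefore holds the lower of the two numbers, and its gap to compound 1 lies beyond the scatter. Within the data shown here, these two compounds are not a pair that differs in one place, and no such pair has been measured.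

Compound 3 `COc1nc2ccc(C#N)cc2cc1[C@@H](c1cccc(C)c1F)[C@@](O)(CCN(C)C)c1cc(SC)nc(SC)c1` has yet to be measured in this assay. It departs from compound 2 in a single place, with methyl in place of methoxy on an aromatic carbon, so that 2-fluoro-3-methoxyphenyl becomes 2-fluoro-3-methylphenyl (methyl in place of methoxy on an aromatic carbon). Among the measured compounds shown here, with no measured step to calibrate this change, the expectation starts from compound 2 at 28% as its anchor. Only a small upward move is foreseen, none of it beyond the scatter, and the estimated move is a number 5 percentage points higher from compound 2 to compound 3 (within the scatter) in size. For compound 3 the expected oral bioavailability is 33% as a central estimate, within an estimated range of 16% to 52% for the coming measurement.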

Compound 3, oral bioavailability: 31%
Beside the measured number, compound 3's estimate is 2 percentage points above it; measured number inside the range.
By their numbers in this assay, from the lowest: compounds 2 and 3 (each within the scatter of the next); then compound 1.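

Among these compounds, with methyl in place of methoxy on an aromatic carbon ortho to a fluoro group, this assay gives a number 3 percentage points higher from compound 2 to compound 3 (within the scatter), so the two compounds cannot be told apart on this read-out, and this swap at this position is the first single change to be read here. The new compound also links the series through a second single change, for with the 2-fluoro-3-methylphenyl group held constant, exchanging the group of 12 heavy atoms on the saturated chain carbon for the group of 10 heavy atoms gives a number 35 percentage points lower from compound 1 to compound 3 (beyond the scatter), a large step that sets the change at that other place far above the methyl for methoxy swap in size. Nothing at hand offers an explanation for either step.

The compounds shown leave open whether a chloro or an ethyl group at the same aromatic carbon would stay within the scatter of methyl and methoxy. Among the compounds shown here, they also leave open whether methyl for methoxy would read the same when the group of 12 heavy atoms is present, since the swap is seen only with the group of 10 heavy atoms.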